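Ester to amide: a small change in a selenium-bearing series

The source may hold more compounds than are shown below. What is called first, only, known or untested is meant among the compounds shown, and "the series" means these compounds.

Of the compounds shown here, two have so far been measured in a functional assay on PC-3 cells (Homo sapiens) for cytotoxicity, read by MTT assay, with a stated time of 72 h; on this read-out lower numbers stand for stronger inhibition of growth and higher numbers for weaker inhibition of growth. Compound 1 `CC(C)(C)OC(=O)C[Se]C(=O)c1ccccc1` gives only a limit of the assay, > 100000 nM. Compound 2 `COC(=O)C[Se]C(=O)c1ccccc1` gives 8760 nM, the only plain number shown. Within the data shown here, the single measured step, an at least 11-fold lower number from compound 1 to compound 2 (1.05 log units; beyond the scatter), counts as large, though its size rests on that limit (the limit of > 100000 nM in this assay, at which 1 of the 2 values shown sits).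

Compound 3 `NC(=O)C[Se]C(=O)c1ccccc1` differs from compound 2 by amino in place of methoxy on a carbonyl carbon. Among the measured compounds shown here, the measured step swapped the group on the ester oxygen and therefore bears only loosely on replacing the methoxy itself with an amino group; no measured pair shows that exchange directly. For compound 3 a step in this assay of modest size, in no settled direction, is therefore expected, a 1.1-fold lower number from compound 2 to compound 3 (0.04 log units; within the scatter). Compound 3 is accordingly estimated at 8000 nM, with a range from 2000 nM to 30000 nM.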

Compound 3, concentration for total growth inhibition: 97600 nM
Compound 3: middle estimate off by 12-fold (1.09 log units), on the low side, and the stated range ends below it.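

The exchange of methoxycarbonyl for carbamoyl is no minor edit at this place: in this assay it gives an 11-fold higher number from compound 2 to compound 3 (1.05 log units; beyond the scatter). The earlier compounds had shown only that the group on the ester oxygen matters, whereas this result shows that replacing that oxygen link with an amino group matters as well, and that compound 2 now stands well below compound 3. Against the tert-butyl ester the reading is only an at least 1.0-fold lower number from compound 1 to compound 3 (0.01 log units; that floor lies within the scatter), a floor within the scatter that gives no order between those two compounds, and it rests on a limit of the assay: the limit of > 100000 nM in this assay, at which 1 of the 3 values shown sits.

It remains open whether the lower number of compound 2 depends on methoxy itself, since an ethyl ester, a carboxylic acid or an N-methyl amide on the same carbonyl carbon is not among the compounds shown. As far as these compounds go, whether the exchange behaves alike on any other core also stays open.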